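Rat microsome stability: from compound 3 to compound 4

This account rests on a few compounds, and the source may have more. Where it says the series, first, only, none or still open, it means among the compounds named here.

Measured in an ADME assay (liver) for metabolic stability, with Liver microsome (Rattus norvegicus) as the target, read by LC-MS, using microsomes, with a stated time of 30 min, tested at 4 uM; on this read-out higher numbers stand for a more stable compound and lower numbers for a less stable compound:
- compound 1 `CCN1CCN(c2nc(C)nc3c2nc(-c2ccccc2Cl)n3C)CC1`: 30%
- compound 2 `Cc1nc(N2CCN(C)CC2)c2nc(-c3ccccc3Cl)n(CCN3CCCC3=O)c2n1`: 28%
- compound 3 `Cc1nc(N2CCN(C)CC2)c2nc(-c3cccc(Cl)c3)n(C3CCOCC3)c2n1`: 45%

In this assay, compound 3 at 45% stands highest of the three, beyond the scatter above both compound 1 and compound 2. The next compound, compound 4 `Cc1nc(N2CCN(C)CC2)c2nc(-c3ccccc3C3CC3)n(C3CCOCC3)c2n1`, keeps the oxan-4-yl group of compound 3 and changes only the aryl group: 2-cyclopropylphenyl in place of 3-chlorophenyl on an aromatic carbon. The new group has 2-cyclopropylphenyl in place of 3-chlorophenyl on an aromatic carbon.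

Within the data shown here, no measured pair isolates a single change, so no direct step supports this expectation. Among the measured compounds shown here, the only guide is the spread of values, with compound 1 at 30% and compound 2 at 28% as the lower reference points. A modest fall is expected, possibly not beyond the scatter. The expected change is a number 8 percentage points lower from compound 3 to compound 4 (within the scatter). For compound 4 the estimate is 37%, with an expected range of 22% to 52%.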

Compound 4, percent of the compound remaining: 67%
Beside the measured number, compound 4's estimate is 30 percentage points below it; the whole stated range lies below it.
By their numbers in this assay, from the lowest: compounds 2 and 1 (each within the scatter of the next); then compound 3; then compound 4.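

In this assay, the aromatic carbon bearing the aryl group, next to the ring atom that bears the oxan-4-yl group, proves responsive to a single change: 2-cyclopropylphenyl in place of 3-chlorophenyl gives a number 22 percentage points higher from compound 3 to compound 4 (beyond the scatter). Among these compounds, this is the first single-place step, and it shows that the aryl group alone can move this read-out beyond the scatter with the oxan-4-yl group held constant. No available evidence bears on the origin of this rise.

The step changes both the substituent and its place on the phenyl ring, so the compounds shown do not separate those two contributions. A 3-cyclopropylphenyl or 2-methylphenyl group at the same carbon, with the rest of compound 4 unchanged, would address whether the cyclopropyl ring or its placement tracks with the higher number.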